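Trifluoromethyl in place of fluoro on a shared core

A few compounds are considered here, and "the series" means these few. Any claim that something is new, unique, unknown or untested is made for them only; others in the source may bear on it.

Among the compounds with values here, compound 2 `Oc1ccc(-c2cc(-c3ccccc3F)cc(-c3cccc(O)c3)n2)cc1` gives 5630 nM in a functional assay on HCT-15 cells (Homo sapiens) for inhibition (a higher number here means a weaker inhibitor, a lower number a stronger inhibitor), the highest of the two numbers measured so far; compound 1 `Oc1cccc(-c2cc(-c3ccccc3F)cc(-c3cccc(O)c3)n2)c1` gives 5300 nM, and the step of a 1.1-fold higher number from compound 1 to compound 2 (0.03 log units; within the scatter) lies within the scatter. Compound 3 `Oc1ccc(-c2cc(-c3ccccc3C(F)(F)F)cc(-c3cccc(O)c3)n2)cc1` differs from compound 2 by trifluoromethyl in place of fluoro on an aromatic carbon. Within the data shown here, no measured step touches this group: the single measured step concerns the hydroxyphenyl group, not the fluoro. With nothing to rest on, the expected step of a 1.0-fold lower number from compound 2 to compound 3 (0.00 log units; within the scatter) is none beyond the scatter. Compound 3 is therefore estimated at 5600 nM, within a range from 2500 nM to 12500 nM.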

Compound 3, half-maximal inhibitory concentration: 5740 nM
Beside the measured number, compound 3's estimate is 1.0-fold (0.01 log units) below it; the measured number falls inside the stated range.
By their numbers in this assay, from the lowest: compounds 1, 2 and 3 (each within the scatter of the next).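

The earlier compounds shown here varied only the hydroxyphenyl group, whereas here 2-fluorophenyl becomes 2-(trifluoromethyl)phenyl, and this assay shows a 1.0-fold higher number from compound 2 to compound 3 (0.01 log units; within the scatter) for this exchange. At this place, on an aromatic carbon ortho to a large group, the shared core therefore reads the same with trifluoromethyl as with fluoro. No available evidence accounts for this result. On these data alone, whether an amine or a carboxylic acid at this place would give a different number remains open, and so does the effect of a longer chain.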